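The compounds below may be only part of what the source reports. "The series", "measured", "known", "first", "only" and "open" are said of these compounds alone.

Series notes. Compound 2 `CC(C)(C)c1ccc(CN2CCN(C(=O)CCc3cc(-c4ccc(F)cc4)n(-c4ccccc4)n3)CC2)cc1` is the reference point; in an assay on isolated protein for inhibition of Polyunsaturated fatty acid 5-lipoxygenase (Homo sapiens), read by HPLC, with a stated time of 15 min, in the presence of a further agent that is not named here (a higher number here means a weaker inhibitor, a lower number a stronger inhibitor), compound 2 gives 2500 nM. Among the compounds with values here, of the two numbers measured so far, compound 2 holds the lowest, and its nearest neighbour is compound 3 `CC(C)(C)c1ccc(CN2CCN(C(=O)CCc3cc(-c4ccc(C(F)(F)F)cc4)n(-c4ccccc4)n3)CC2)cc1`, which in this assay gives 2900 nM; the step of a 1.2-fold higher number from compound 2 to compound 3 (0.06 log units; within the scatter) keeps the pair within the scatter. For compound 1 `Cc1ccc(-c2cc(CCC(=O)Oc3ccc(OC(F)(F)F)cc3)nn2-c2ccc(Cl)nn2)cc1` the entry in this assay is "not determined" (no result reported). The new entry is compound 4 `COc1ccc(-n2nc(CCC(=O)N3CCN(Cc4ccc(C(C)(C)C)cc4)CC3)cc2-c2ccc(F)cc2)nn1`, which differs from compound 2 by 6-methoxypyridazin-3-yl in place of phenyl on an aromatic nitrogen. Within the data shown here, no measured step touches this position; the single recorded step a 1.2-fold higher number from compound 2 to compound 3 (0.06 log units; within the scatter) concerns a different change and was itself within the scatter, so it gives no direction. The step of no change at the digits printed from compound 2 to compound 4 (within the scatter) is therefore expected to stay within the scatter. The estimate for compound 4 is 2500 nM, with a range from 800 nM to 8000 nM.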

Compound 4, half-maximal inhibitory concentration: > 10000 nM
Compound 4 was reported as a limit; the forecaster's own chance of this, stated with the estimate: 10%; at least 4.0-fold (0.60 log units) between middle value and limit.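

In this assay, within the data shown here, 6-methoxypyridazin-3-yl in place of phenyl on the aromatic nitrogen gives an at least 4.0-fold higher number from compound 2 to compound 4 (0.60 log units; beyond the scatter), the first step beyond the scatter. The earlier step, a 1.2-fold higher number from compound 2 to compound 3 (0.06 log units; within the scatter), showed no such shift, though it concerned a different position. The entry for compound 4 is a limit and not a number: the limit of > 10000 nM in this assay, at which 1 of the 4 values shown sits.

This single exchange changes both the ring atoms and the methoxy group, and the compounds shown do not separate the two. As far as these compounds go, whether an unsubstituted pyridazin-3-yl or a 4-methoxyphenyl group on this nitrogen would read like compound 2 stays open.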